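A Phenyl-to-Bromofluorophenyl Swap Tried on a Second Core

This account rests on a few compounds, and the source may have more. Where it says the series, first, only, none or still open, it means among the compounds named here.

Compound 1 `O=C(Nc1ccc(Oc2ccnc3[nH]ccc23)c(F)c1)c1nn(-c2ccccc2)ccc1=O`: 38600 nM
Compound 2 `O=C(Nc1ccc(Oc2ccnc3[nH]ccc23)c(F)c1)c1nn(-c2ccc(Br)cc2F)ccc1=O`: 8800 nM
Compound 3 `Cn1ccc2c(Oc3ccc(NC(=O)c4nn(-c5ccccc5)ccc4=O)cc3)ccnc21`: 58200 nM

The three measured compounds were all tested in a functional assay on PC-3 cells (Homo sapiens) for cytotoxicity, read by MTT assay, with a stated time of 72 h; a higher number here means a weaker inhibitor, a lower number a stronger inhibitor. Compound 1 and compound 2 share one core and differ only on an aromatic nitrogen, where compound 2 carries 4-bromo-2-fluorophenyl in place of phenyl on an aromatic nitrogen. That single change gave a 4.4-fold lower number from compound 1 to compound 2 (0.64 log units; beyond the scatter), a gain that stands outside the ordinary scatter of this assay.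

Compound 3 is built on a different core; how its core differs from that of compound 1 is not broken down here. In this assay compound 3 gives 58200 nM, and compound 1 gives 38600 nM, two numbers that lie within the scatter of each other, so no order can be read between them. Compound 2 sits clearly lower than both.

Compound 4 `Cn1ccc2c(Oc3ccc(NC(=O)c4nn(-c5ccc(Br)cc5F)ccc4=O)cc3)ccnc21` has not yet been measured. It stands to compound 3 exactly as compound 2 stands to compound 1: on an aromatic nitrogen it carries 4-bromo-2-fluorophenyl in place of phenyl on an aromatic nitrogen, and the surroundings of that place are the same in words as in the first pair. Within the data shown here, since the same change on the first core produced a 4.4-fold lower number from compound 1 to compound 2 (0.64 log units; beyond the scatter), compound 4 is expected to show a step of about a 4.5-fold lower number from compound 3 to compound 4 (0.65 log units; beyond the scatter) from compound 3, with a wider band of doubt because only one earlier example supports it. Compound 4 is therefore estimated at 13000 nM in this assay, most likely between 5000 nM and 35000 nM.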

Compound 4, half-maximal inhibitory concentration: 20500 nM
Compound 4: the middle estimate sits 1.6-fold (0.20 log units) below what was measured; measured number inside the range.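

On the core of compound 3, putting 4-bromo-2-fluorophenyl in place of phenyl gave a 2.8-fold lower number from compound 3 to compound 4 (0.45 log units; beyond the scatter) in this assay, so the change moved the number in the same direction as it did on the core of compound 1. Set side by side, the two steps agree in direction, and the gap between their sizes is no larger than repeated measurements would be expected to produce: the same change on two cores in this assay, a 4.4-fold lower number (0.64 log units; beyond the scatter) from compound 1 to compound 2 and a 2.8-fold lower number (0.45 log units; beyond the scatter) from compound 3 to compound 4, 1.5-fold (0.19 log units) apart, within the scatter of two such steps This shows that the change carried over between these two cores in this one cell assay, but two cores are too few to promise the same step on any other core, and the numbers alone do not explain why the step occurs.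

The compounds shown leave open whether the bromine, the fluorine or the two together account for the step, as each appears here only alongside the other on the phenyl ring. They also leave open what would happen with something other than a phenyl ring on that aromatic nitrogen, such as an amine, a carboxylic acid or a longer chain.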